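Chloro to bromo on the aryl of compound 3

The source may hold more compounds than are shown below. What is called first, only, known or untested is meant among the compounds shown, and "the series" means these compounds.

Compound 1 `C/C(=N\Nc1nc(-c2ccccc2)cs1)c1sc(-c2ccccc2)nc1C`: in a toxicity assay on MCF7 cells (Homo sapiens) for cytotoxicity, read by MTT assay (on this read-out higher numbers stand for weaker inhibition of growth and lower numbers for stronger inhibition of growth), compound 1 gives > 100 ug/mL, a limit of the assay.
Compound 2 `C/C(=N\Nc1nc(-c2ccc(F)cc2)cs1)c1sc(-c2ccccc2)nc1C`: in this assay compound 2 gives > 100 ug/mL, a limit.
Compound 3 `C/C(=N\Nc1nc(-c2ccc(Cl)cc2)cs1)c1sc(-c2ccccc2)nc1C`: in this assay compound 3 gives > 100 ug/mL, a limit.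

Compound 3 therefore stands at the limit of > 100 ug/mL in this assay, at which 3 of the 3 values shown sit, and no number separates it from the others. Compound 4 `C/C(=N\Nc1nc(-c2ccc(Br)cc2)cs1)c1sc(-c2ccccc2)nc1C` differs from it by bromo in place of chloro on an aromatic carbon. The measured steps that bear on this exchange are a step that the two limits leave unreadable from compound 1 to compound 2, a step that the two limits leave unreadable from compound 1 to compound 3 and a step that the two limits leave unreadable from compound 2 to compound 3, all of them unreadable in size. The step from compound 3 to compound 4 is thus expected as a number no higher from compound 3 to compound 4 (the limit leaves the size open), with no shift beyond the scatter. Compound 4 is estimated at 100 ug/mL, between 50 ug/mL and 200 ug/mL, most likely again reported only as a limit.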

Compound 4, concentration for 50% growth inhibition: 26.3 ug/mL
For compound 4 the middle estimate is 3.8-fold (0.58 log units) above the measured one, outside the stated range (below it).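

At the place para to a large group, the aryl substituent now shows an effect in this assay: bromo gives an at least 3.8-fold lower number from compound 3 to compound 4 (0.58 log units; beyond the scatter), and the comparisons with fluoro and hydrogen give an at least 3.8-fold lower number from compound 2 to compound 4 (0.58 log units; beyond the scatter) and an at least 3.8-fold lower number from compound 1 to compound 4 (0.58 log units; beyond the scatter). For the compounds shown here, the steps among compound 1, compound 2 and compound 3 cannot be read, so the earlier compounds showed no such effect. Compound 4 alone gives a number rather than a limit: the limit of > 100 ug/mL in this assay, at which 3 of the 4 values shown sit.

As far as these compounds go, the full size of these steps stays open. So does whether an amine, a methoxy group or a carboxylic acid at this place would give a number rather than a limit.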